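Working notes: removal of the distal phenyl in the series

The source may hold more compounds than are shown below. What is called first, only, known or untested is meant among the compounds shown, and "the series" means these compounds.

Of the compounds shown here, two have been measured so far. Compound 1 `O=C(CC1c2ccccc2N=C(SCCCCCN2CCCC2)N1c1ccc(-c2ccccc2)cc1)NCc1ccc(F)cc1` gives, in an assay on cells for inhibition of Voltage-dependent T-type calcium channel subunit alpha-1G (Homo sapiens), read by patch clamp (a higher number here means a weaker inhibitor, a lower number a stronger inhibitor), compound 1 a value of 15000 nM. Compound 2 `CN(C)CCCCCSC1=Nc2ccccc2C(CC(=O)NCc2ccccc2)N1c1ccc(-c2ccccc2)cc1` gives in this assay a value of 7770 nM. Compound 1 thus has the highest of the two numbers, but its nearest neighbour, compound 2, lies within the scatter of it, so the two are not separated.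

Compound 3 `O=C(CC1c2ccccc2N=C(SCCCCCN2CCCC2)N1c1ccccc1)NCc1ccc(F)cc1` has not yet been measured. It differs from compound 1 in one place: hydrogen in place of phenyl on an aromatic carbon. The same difference, cut one bond further out, reads 4-phenylphenyl to phenyl. Among the measured compounds shown here, no pair of measured compounds shows this change, so its size is unknown from the data at hand; both measured compounds carry the 4-phenylphenyl group.

The expectation is that the step from compound 1 to compound 3 in this assay will be modest and towards a higher number, i.e. a 1.7-fold higher number from compound 1 to compound 3 (0.22 log units; within the scatter). On that basis compound 3 is estimated at 25000 nM in this assay, with a range from 8000 nM to 80000 nM.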

Compound 3, half-maximal inhibitory concentration: 13500 nM
Beside the measured number, compound 3's estimate is 1.9-fold (0.27 log units) above it, within the range that was stated.
By their numbers in this assay, from the lowest: compounds 2, 3 and 1 (each within the scatter of the next).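

In this assay, the change from 4-phenylphenyl to phenyl can now be read directly, and hydrogen in place of phenyl on this aromatic carbon gives a 1.1-fold lower number from compound 1 to compound 3 (0.05 log units; within the scatter). Both earlier compounds carried the 4-phenylphenyl group, so they left the size of this step unknown; the pair now shows that, on the background of compound 1, losing these 6 heavy atoms does not shift the number beyond the scatter. Nothing at hand gives a reason for this result.

As far as these compounds go, this reading rests on a single pair, so it remains open whether the same change would also stay within the scatter on the background of compound 2, which carries a different side chain and a different amide group from compound 1. Also open, from the compounds shown here alone, is whether a group other than hydrogen or phenyl on this carbon, such as a methoxy group, a chlorine atom, an amine or a carboxylic acid, would move the number in this assay beyond the scatter.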